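The source may report more compounds than this note shows. Statements on the series, on what has been measured and on what is new or still open speak of the compounds shown alone.

Measured compounds:
compound 1 `C#CCN(Cc1ccc(OCc2cccc(F)c2)cc1)[C@@H](C)C(N)=O` — 530 nM in an assay on Sf9 cells for inhibition of Amine oxidase [flavin-containing] B (Homo sapiens), with stated times of 15 min and 60 min; on this read-out lower numbers stand for stronger inhibition and higher numbers for weaker inhibition
compound 2 `NC(=O)[C@@H]1CCN1Cc1ccc(OCc2cccc(F)c2)cc1Cl` — 35 nM in this assay
compound 3 `C[C@H](NCc1ccc(OCc2cccc(F)c2)cc1Cl)C(N)=O` — 28 nM in this assay

Compound 2 gives the second highest of the three numbers in this assay. Its nearest neighbour is compound 3, and the step of a 1.3-fold lower number from compound 2 to compound 3 (0.10 log units; within the scatter) lies within the scatter. Compound 1, which carries no halogen on the shared core and a different amine, gives a number well above that of compound 2.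

Compound 4 `NC(=O)[C@@H]1CCN1Cc1ccc(OCc2cccc(F)c2)cc1F` has not yet been measured. It differs from compound 2 in one place: fluoro in place of chloro on an aromatic carbon. For the measured compounds named here, no measured step changes only this halogen. The one step shown, from compound 2 to compound 3, alters the amine and not the halogen, so it does not bear on the change at hand. The gap between compound 1 and compound 2 involves two changes at once, and only the two values themselves can be read from it.

Going by the values given here, with no halogen step to lean on, compound 4 is expected to stay close to compound 2, with a modest shift toward a higher number allowed for: the expected step is a 1.9-fold higher number from compound 2 to compound 4 (0.27 log units; within the scatter). The estimate for compound 4 in this assay is 65 nM, within a range from 25 nM to 180 nM.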

Compound 4, half-maximal inhibitory concentration: 26 nM
The estimate for compound 4 lay 2.5-fold (0.40 log units) above the measured number; the measured number falls inside the stated range.
By their numbers in this assay, from the lowest: compounds 4, 3 and 2 (each within the scatter of the next); then compound 1.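

For the compounds shown here, the step of a 1.3-fold lower number from compound 2 to compound 4 (0.13 log units; within the scatter) in this assay is the first reading in which only the halogen changes on this aromatic carbon, ortho to the (2-carbamoylazetidin-1-yl)methyl group. Going by these compounds alone, with that group in place, the read-out does not separate fluoro from chloro at this position, a point that the earlier compounds, which changed the amine or changed two places at once, could not settle. Nothing measured here offers a reason for this result.

On these data alone, what a hydrogen, a methyl group, a methoxy group or a nitrile would do at this carbon remains open, and compound 1 cannot answer this, since its amine differs as well. Also open, as far as these compounds go, is whether fluoro and chloro would stay equally close with the (1-carbamoylethyl)amino group of compound 3 in place of the 2-carbamoylazetidin-1-yl group.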